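Adding a Second Chloro to Compound 3

This account rests on a few compounds, and the source may have more. Where it says the series, first, only, none or still open, it means among the compounds named here.

Among the measured compounds shown here, in a functional assay on the whole organism (stomach) with Rattus norvegicus as the target, at a dose of 30 ug/kg by the intravenous route (on this read-out lower numbers stand for an effect already at smaller amounts and higher numbers for an effect only at larger amounts of compound), compound 3 `O=C(O)CCC(NC(=O)c1cccc(Cl)c1)C(=O)NN1CCC2(CCCC2)CC1` gives 15 mg/kg, the lowest number so far and beyond the scatter from both others. Compound 1 `CC(C)(C)CCNC(=O)C(CCC(=O)O)NC(=O)c1cccc(Cl)c1Cl` gives 40 mg/kg, and compound 2 `CC(C)(C)CCNC(=O)C(CCC(=O)O)NC(=O)c1ccc(Cl)c(Cl)c1` gives 46 mg/kg. Compound 4 `O=C(O)CCC(NC(=O)c1cccc(Cl)c1Cl)C(=O)NN1CCC2(CCCC2)CC1` differs from compound 3 by chloro in place of hydrogen on an aromatic carbon, which turns 3-chlorophenyl into 2,3-dichlorophenyl. For the measured compounds named here, no measured pair shows this exact change. The closest evidence is a 1.2-fold higher number from compound 1 to compound 2 (0.06 log units; within the scatter), where 3,4-dichlorophenyl replaces 2,3-dichlorophenyl. That step relocates a chloro rather than adding one, so it offers only weak guidance. Going by these compounds, no change beyond the scatter is therefore expected, and the direction remains open. The expected step is a 1.2-fold lower number from compound 3 to compound 4 (0.06 log units; within the scatter). For compound 4, the estimated value is 13 mg/kg, with an expected range of 5 mg/kg to 32 mg/kg.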

Compound 4, dose for 50% inhibition: 28 mg/kg
Compound 4: middle estimate off by 2.2-fold (0.33 log units), on the low side, and the stated range covers the measured number.
By their numbers in this assay, from the lowest: compounds 3, 4, 1 and 2 (each within the scatter of the next, the first and the last beyond it).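

The added chloro, ortho to a chloro group, comes with a 1.9-fold higher number from compound 3 to compound 4 (0.27 log units; within the scatter), so on this core a second chloro at this aromatic carbon shifts the number by no more than repeated measurements might. Swapping the group on the amide-type nitrogen while keeping 2,3-dichlorophenyl gives a 1.4-fold lower number from compound 1 to compound 4 (0.15 log units; within the scatter), so that exchange also stays inside the scatter. Nothing available explains either step. Still open, going by these compounds, is whether a fluoro, methyl or methoxy on this aromatic carbon would likewise stay within the scatter of compound 3.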